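Trimethoxyphenyl in place of phenyl on the amide nitrogen

The source may report more compounds than this note shows. Statements on the series, on what has been measured and on what is new or still open speak of the compounds shown alone.

Among the measured compounds shown here, compound 2 `O=C(Nc1ccccc1)c1csc(-c2cn(Cc3ccc(Cl)cc3)c3ccccc23)n1` is the only member of this set with a number: in a functional assay on PC-3 cells (Homo sapiens) for cytotoxicity, read by MTT assay, with a stated time of 48 h, in the absence of a further agent (a higher number here means a weaker inhibitor, a lower number a stronger inhibitor), compound 2 gives 76400 nM. Compound 1 `COc1ccc(NC(=O)c2csc(-c3cn(Cc4ccc(Cl)cc4)c4ccccc34)n2)cc1` returns only a limit of the assay, > 100000 nM. Compound 3 `O=C(Nc1ccccc1)c1csc(-c2c[nH]c3ccccc23)n1` likewise returns only a limit, > 100000 nM. Two of the three results therefore rest at the limit of > 100000 nM in this assay, at which 2 of the 3 values shown sit, and compound 2 stands alone as the one measured potency. The step of an at least 1.3-fold lower number from compound 1 to compound 2 (0.11 log units; that floor lies within the scatter) and the step of an at least 1.3-fold higher number from compound 2 to compound 3 (0.11 log units; that floor lies within the scatter) are both floors that lie within the scatter, so neither shows a change that can be trusted.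

Compound 4 `COc1cc(NC(=O)c2csc(-c3cn(Cc4ccc(Cl)cc4)c4ccccc34)n2)cc(OC)c1OC` differs from compound 2 by 3,4,5-trimethoxyphenyl in place of phenyl on an amide-type nitrogen. Of the measured steps only the change from compound 1 to compound 2 touches the same group on the amide-type nitrogen; there, removing a methoxy gave a number at least slightly lower, so adding three methoxy groups is expected to move the number the other way, though that step was itself within the scatter. A modest upward step a 1.6-fold higher number from compound 2 to compound 4 (0.20 log units; within the scatter) is expected, with a real chance that only a limit is reported. Compound 4 is estimated at 120000 nM, within 40000 nM to 400000 nM.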

Compound 4, half-maximal inhibitory concentration: > 100000 nM
Compound 4 ended at the assay's limit; the forecaster's own chance of this, stated with the estimate: 60%; the middle value lies beyond the limit too.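

In this assay, 3,4,5-trimethoxyphenyl in place of phenyl on an amide-type nitrogen gives an at least 1.3-fold higher number from compound 2 to compound 4 (0.11 log units; that floor lies within the scatter), so this larger group brings no readable change at this position. The step from compound 1 to compound 4 cannot be read, as both values are limits, and the data therefore do not separate 4-methoxyphenyl from 3,4,5-trimethoxyphenyl on this nitrogen. Both methoxy-bearing compounds now end without a number, yet compound 3, which carries plain phenyl, ends the same way, so methoxy alone does not account for the picture, and the series now sits mostly at one value: the limit of > 100000 nM in this assay, at which 3 of the 4 values shown sit.

Still open, from the compounds shown here alone, is whether an amine or a carboxylic acid on the phenyl, or a longer chain in place of the phenyl on the amide-type nitrogen, would give a number that differs from that of compound 2 beyond the scatter. Also open, going by these compounds, is how far compound 1, compound 3 and compound 4 really lie from compound 2, since a limit gives no size for any of these three.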